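This account rests on a few compounds, and the source may have more. Where it says the series, first, only, none or still open, it means among the compounds named here.

Compound 1 `Fc1ccc(-c2ccc(-c3ccc(-c4nc5ccccc5[nH]4)cc3)cc2)cc1` gives 48200 nM in a functional assay on A2780 cells (Homo sapiens) for inhibition, read by sulforhodamine B assay (on this read-out lower numbers stand for stronger inhibition of growth and higher numbers for weaker inhibition of growth), a weak level of growth inhibition. Compound 3 `Oc1ccc(-c2ccc(-c3ccc(-c4nc5ccccc5[nH]4)cc3)cc2)cc1` gives 36000 nM, and a 1.3-fold lower number from compound 1 to compound 3 (0.13 log units; within the scatter) stays within the scatter. Compound 2 `FC(F)(F)c1ccc(-c2ccc(-c3ccc(-c4nc5ccccc5[nH]4)cc3)cc2)cc1` gives 100000 nM, the highest number of the three, with a 2.1-fold higher number from compound 1 to compound 2 (0.32 log units; beyond the scatter) and a 2.8-fold lower number from compound 2 to compound 3 (0.44 log units; beyond the scatter), both modest.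

Compound 4 `Oc1cccc2[nH]c(-c3ccc(-c4ccc(-c5ccc(F)cc5)cc4)cc3)nc12` keeps the core of compound 1 and adds hydroxy in place of hydrogen on an aromatic carbon, on the six-membered ring of carbon only that is part of the fused system. Within the data shown here, no measured compound carries a change on that ring, so the evidence is indirect. The three measured steps all replace a group elsewhere, and the one closest in kind, hydroxy for fluoro in compound 3, gave a 1.3-fold lower number from compound 1 to compound 3 (0.13 log units; within the scatter). A small change is therefore expected in this assay, perhaps slightly lower and probably not beyond the scatter. The estimated change is a 1.5-fold lower number from compound 1 to compound 4 (0.16 log units; within the scatter). For compound 4 the estimate is 33000 nM, with an expected range of 12000 nM to 85000 nM.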

Compound 4, concentration for 50% growth inhibition: 41200 nM
Compound 4: middle estimate off by 1.2-fold (0.10 log units), on the low side; the measured number falls inside the stated range.
By their numbers in this assay, from the lowest: compounds 3, 4 and 1 (each within the scatter of the next); then compound 2.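

Hydroxy in place of hydrogen on an aromatic carbon of the six-membered aromatic ring of carbon only, part of a fused or bridged system of two rings, gives a 1.2-fold lower number from compound 1 to compound 4 (0.07 log units; within the scatter) in this assay and stays within the scatter. Among these compounds, the earlier steps exchanged fluoro, trifluoromethyl and hydroxy elsewhere on the molecule, so this is the first sign that this ring of the core also accepts a new group without a step beyond the scatter, although growth inhibition remains weak. No measurement at hand bears on the reason for this result.

On these data alone, whether an amine or a carboxylic acid at this place would stay within the scatter remains open. Also open, as far as these compounds go, is whether hydroxy on the other carbons of this ring would behave as it does here.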